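The source may report more compounds than this note shows. Statements on the series, on what has been measured and on what is new or still open speak of the compounds shown alone.

Measured so far in a functional assay on MCF7 cells (Homo sapiens) for antiproliferative activity, read by MTT assay; a lower number here means a stronger inhibitor, a higher number a weaker inhibitor:

- compound 1, `CC/C=C\C/C=C\C/C=C\CCCCCCCC1(O)CC(=O)c2c(O)cc(OCOC)cc2O1`: 17500 nM
- compound 2, `CCCCC/C=C\C/C=C\CCCCCCCC1(O)CC(=O)c2c(O)cc(OCOC)cc2O1`: > 84100 nM, which is a limit of the assay and not a number
- compound 3, `CCCCC/C=C\C/C=C\CCCCCCCC1(O)CC(=O)c2c(O)c(C)c(O)c(C)c2O1`: 43200 nM

Compound 1 and compound 2 share one core and differ only in but-1-en-1-yl in place of butyl on a saturated chain carbon bound to a double-bonded chain carbon. That change gives an at least 4.8-fold lower number from compound 2 to compound 1 (0.68 log units; beyond the scatter). The step is known only as a bound because the limit of > 84100 nM in this assay, at which 1 of the 3 values shown sits, is where compound 2 sits.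

Compound 3 has a different core; the difference between the two cores is not broken down here. In this assay compound 3 gives the highest of the two numbers, with compound 1 nearest to it by a margin beyond the scatter.

Compound 4, `CC/C=C\C/C=C\C/C=C\CCCCCCCC1(O)CC(=O)c2c(O)c(C)c(O)c(C)c2O1`, has not yet been measured in this assay. It differs from compound 3 by but-1-en-1-yl in place of butyl on a saturated chain carbon bound to a double-bonded chain carbon. This is the same change as the one between compound 2 and compound 1, made at the same place, so the earlier step is the only guide to its size; the change occurs twice among the compounds shown.

Compound 4 is expected to sit lower than compound 3 by roughly a 4.8-fold lower number from compound 3 to compound 4 (0.68 log units; beyond the scatter). That expectation rests on the bound given by an at least 4.8-fold lower number from compound 2 to compound 1 (0.68 log units; beyond the scatter), applied to the value of compound 3; as the earlier step is only a bound, the true drop could be larger. Compound 4 is estimated at 9000 nM, most likely between 3000 nM and 25000 nM.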

Compound 4, half-maximal inhibitory concentration: 43200 nM
Beside the measured number, compound 4's estimate is 4.8-fold (0.68 log units) below it; measured number above the stated range.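

In this assay, but-1-en-1-yl in place of butyl on a saturated chain carbon bound to a double-bonded chain carbon gives no change at the digits printed from compound 3 to compound 4 (within the scatter), so the gain seen on the core of compound 1 does not reappear on the core of compound 3. On these two cores, the size of this change therefore depends on the core it is made on: the same change on two cores in this assay, an at least 4.8-fold lower number (0.68 log units; beyond the scatter) from compound 2 to compound 1 and no change at the digits printed (within the scatter) from compound 3 to compound 4, at least 4.8-fold (0.68 log units) apart, beyond the scatter of two such steps

This does not give a rule for the series, since two cores are too few for one, the cores are not broken down into single differences, and the size of the earlier step remains open, as it ends on a limit and not on a number: the limit of > 84100 nM in this assay, at which 1 of the 4 values shown sits.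

The compounds shown leave open whether a third core would respond as the core of compound 1 does or as the core of compound 3 does. They also leave open how this assay would read for a longer chain, a shorter chain, or a chain ending in an amine or a carboxylic acid on either core.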